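From 4-methoxyphenyl to 2-iodophenyl on the sulfonyl sulfur

The compounds below may be only part of what the source reports. "The series", "measured", "known", "first", "only" and "open" are said of these compounds alone.

Of the compounds shown here, two sharing one core have been measured so far in a functional assay on SGC-7901 cells (Homo sapiens) for antiproliferative activity, read by MTT assay, with a stated time of 48 h; on this read-out lower numbers stand for an effect already at smaller amounts and higher numbers for an effect only at larger amounts of compound. Compound 1 `CC1=NN(S(=O)(=O)c2ccc(Cl)cc2Cl)C(c2cc(Br)ccc2O)C1` gives > 60000 nM, which is a limit of the assay and not a number. Among the compounds with values here, compound 2 `COc1ccc(S(=O)(=O)N2N=C(C)CC2c2cc(Br)ccc2O)cc1` gives 21100 nM, the only actual number available. Compound 3 `CC1=NN(S(=O)(=O)c2ccccc2I)C(c2cc(Br)ccc2O)C1` carries 2-iodophenyl in place of 4-methoxyphenyl on a sulfonyl sulfur. Within the data shown here, the only measured step that bears on this change is an at least 2.8-fold lower number from compound 1 to compound 2 (0.45 log units; beyond the scatter), where 4-methoxyphenyl replaced 2,4-dichlorophenyl at that same place and the number fell beyond the scatter. One step is thin evidence, but here 4-methoxyphenyl leaves again, so the number is expected to rise modestly, with an estimated change of a 2.1-fold higher number from compound 2 to compound 3 (0.33 log units; beyond the scatter). For compound 3 the estimated value is 45000 nM, with an expected range from 15000 nM to 120000 nM.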

Compound 3, half-maximal effective concentration: > 60000 nM
Compound 3 was reported as a limit (the forecaster's own chance of this, stated with the estimate: 40%); middle value at least 1.3-fold (0.12 log units) away from the limit.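

With 2-iodophenyl in place of 4-methoxyphenyl on the sulfonyl sulfur, this assay shows an at least 2.8-fold higher number from compound 2 to compound 3 (0.45 log units; beyond the scatter). This is a second replacement of 4-methoxyphenyl at this place that ends at a limit of the assay rather than at a number, so among the three compounds only the 4-methoxyphenyl group gives a measurable value. Both halogen-carrying groups, 2,4-dichlorophenyl in compound 1 and 2-iodophenyl in compound 3, sit at a limit, so the step between those two compounds cannot be read: the limit of > 60000 nM in this assay, at which 2 of the 3 values shown sit.

From the compounds shown here alone, what a plain phenyl, or a phenyl carrying an ethoxy group or an amine, would give at this place stays open. Also open, going by these compounds, is whether any group on the sulfonyl sulfur can bring the number well below that of compound 2 at 21100 nM.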